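A few compounds are considered here, and "the series" means these few. Any claim that something is new, unique, unknown or untested is made for them only; others in the source may bear on it.

Measured compounds:
- compound 1, `CCC(C(=O)N[C@@H](CC(=O)O)C(C)=O)n1cc(C(C)(C)C)nc(NCc2nonc2C)c1=O`, in an assay for inhibition of Caspase-8 (Homo sapiens); on this read-out higher numbers stand for weaker inhibition and lower numbers for stronger inhibition: 10000 nM
- compound 2, `CCCCCCN(C)CNCC(=O)[C@H](CC(=O)O)NC(=O)C(CC)n1cc(CC)nc(NCc2nonc2C)c1=O`, in this assay: 9540 nM
- compound 3, `CCC(C(=O)N[C@@H](CC(=O)O)C(=O)CSCc1ccccc1)n1ccnc(NCC2COc3ccccc3O2)c1=O`, in this assay: 8220 nM

All three measured compounds sit close together in this assay. Compound 3 carries the smallest of the three numbers, but its gap to compound 2 and its gap to compound 1 both lie within the usual scatter of the assay, so nothing separates the three beyond what repeated measurement would give. Among the measured compounds shown here, no pair of measured compounds differs in one place only, so no single structural step has a measured size here.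

Compound 4, `CCC(C(=O)N[C@@H](CC(=O)O)C(=O)CSCc1ccccc1)n1ccnc(NCCCOC)c1=O`, differs from compound 3 in one place: 2-methoxyethyl in place of 2,3-dihydro-1,4-benzodioxin-2-yl on a saturated chain carbon bound to a nitrogen on an aromatic ring. The part that leaves contributes two rings and the part that enters contributes none, as the count shows. For the measured compounds named here, no measured step speaks to this change, and the three measured compounds, which differ from one another in several places at once, all return nearly the same number. On that ground compound 4 is expected to stay close to compound 3, with a step of a 1.2-fold higher number from compound 3 to compound 4 (0.09 log units; within the scatter) that is expected to be no larger than the scatter. The estimate for compound 4 in this assay is 10000 nM, with a range from 5000 nM to 25000 nM.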

Compound 4, half-maximal inhibitory concentration: 7650 nM
Beside the measured number, compound 4's estimate is 1.3-fold (0.12 log units) above it; measured number inside the range.
By their numbers in this assay, from the lowest: compounds 4, 3, 2 and 1 (each within the scatter of the next).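

Among the compounds shown here, putting 2-methoxyethyl in place of 2,3-dihydro-1,4-benzodioxin-2-yl on a saturated chain carbon bound to a nitrogen on an aromatic ring gives a 1.1-fold lower number from compound 3 to compound 4 (0.03 log units; within the scatter) in this assay, the first step with a measured size at this position. On this pair, the two rings of the leaving group can be exchanged for an open chain with no ring, and the two numbers still cannot be told apart. No measurement at hand accounts for this result.

It remains open whether any group at this position would separate itself from these two compounds, for instance a longer chain, an amine or a carboxylic acid at the end of the chain, since the one exchange shown covers only a ring-bearing group and an ether chain. As far as these compounds go, it is also open whether the same exchange would read the same way on another compound, such as one built on the core of compound 1, or on a compound whose number in this assay lies far lower than those of this pair.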